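The source may report more compounds than this note shows. Statements on the series, on what has been measured and on what is new or still open speak of the compounds shown alone.

Compound 1 `Cc1cc(C#N)cc(C)c1Oc1ccnc(S(=O)(=O)CC(=O)Nc2ccc(Cl)cc2Cl)n1` gives 10400 nM in an ADME assay on MT4 cells (Homo sapiens) for cytotoxicity, read by MTT assay, with a stated time of 4 days; a lower number here means that less compound is tolerated, a higher number that more compound is tolerated. Compound 2 `Cc1cc(C#N)cc(C)c1Oc1ccnc(S(=O)(=O)CC(=O)Nc2cc(Cl)cc(Cl)c2)n1` gives 24000 nM in this assay.

Compound 2 stands highest of the two numbers in this assay; its nearest neighbour is compound 1, and a 2.3-fold higher number from compound 1 to compound 2 (0.36 log units; beyond the scatter) lies beyond the scatter. Compound 3 `Cc1cc(C#N)cc(C)c1Oc1ccnc(S(=O)(=O)CC(=O)Nc2ccc([N+](=O)[O-])cc2)n1` differs from compound 2 by 4-nitrophenyl in place of 3,5-dichlorophenyl on an amide-type nitrogen. Within the data shown here, no measured step replaces a dichlorophenyl with a nitrophenyl, and the one measured step, a shift of chlorine positions, is only modest. Compound 3 is therefore expected to stay close to compound 2, with a 1.0-fold higher number from compound 2 to compound 3 (0.02 log units; within the scatter) not beyond the scatter. The estimate for compound 3 in this assay is 25000 nM, ranging from 8000 nM to 70000 nM.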

Compound 3, half-maximal cytotoxic concentration: 59600 nM
Beside the measured number, compound 3's estimate is 2.4-fold (0.38 log units) below it; the measured number falls inside the stated range.
By their numbers in this assay, from the lowest: compound 1; then compound 2; then compound 3.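

In this assay, the place on the amide-type nitrogen tolerates more than a shift of chlorine positions: 4-nitrophenyl gives a 2.5-fold higher number from compound 2 to compound 3 (0.40 log units; beyond the scatter) and also a 5.7-fold higher number from compound 1 to compound 3 (0.76 log units; beyond the scatter). Of these three compounds, the one without chlorine therefore carries the highest number, so chlorine is not required for a high number here. Nothing at hand explains this rise.

As far as these compounds go, whether the rise belongs to the nitro group itself or to the loss of both chlorines stays open. So does the outcome with an unsubstituted phenyl, or with an amine or a carboxylic acid in place of the nitro group.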